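This account rests on a few compounds, and the source may have more. Where it says the series, first, only, none or still open, it means among the compounds named here.

Measured compounds:
compound 1 `CCCCN(c1nc2c(NC(C)=O)cccc2o1)[C@H](C)c1ccc(-c2ccccc2-c2nnn[nH]2)cc1`: 26.6 nM
compound 2 `C[C@H](c1ccc(-c2ccccc2-c2nc(=O)o[nH]2)cc1)N(CC1CC1)c1nc2c(C(=O)O)cccc2o1`: 7710 nM

In an ADME assay on the whole organism (Macaca fascicularis) for pharmacokinetics, read by LC-MS, using cassette dosing, at a dose of 1 mg/kg by the oral route (a lower number here means less compound in the circulation, a higher number more compound in the circulation at the dose given), compound 1 gives 26.6 nM. Within the data shown here, this is the lowest of the two numbers; the only other compound, compound 2, gives 7710 nM, a gap that lies beyond the scatter. Among the measured compounds shown here, compound 2 differs from compound 1 in several places at once, so no single step between measured compounds is available to guide the reading of compound 3.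

Compound 3 `CCCCN(c1nc2c(-c3ccccn3)cccc2o1)[C@H](C)c1ccc(-c2ccccc2-c2nnn[nH]2)cc1` is the compound not yet measured. It differs from compound 1 in one place: pyridin-2-yl in place of acetamido on an aromatic carbon.

For the measured compounds named here, with no step between measured compounds to rest on, the expectation for compound 3 is an open one. The step from compound 1 to compound 3 is expected to be of modest size, and most likely upward, as a 2.3-fold higher number from compound 1 to compound 3 (0.35 log units; beyond the scatter). Compound 3 is accordingly expected to give 60 nM, within a range from 10 nM to 400 nM.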

Compound 3, maximal plasma concentration: 124 nM
Compound 3: the middle estimate sits 2.1-fold (0.32 log units) below what was measured; the measured number falls inside the stated range.
By their numbers in this assay, from the lowest: compound 1; then compound 3; then compound 2.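

In this assay the aromatic carbon that carries acetamido in compound 1 also tolerates a ring, and pyridin-2-yl in its place gives a 4.7-fold higher number from compound 1 to compound 3 (0.67 log units; beyond the scatter) as a modest change. The swap removes the hydrogen-bond donor, keeps one hydrogen-bond acceptor and adds a six-membered aromatic ring, but this single step cannot separate those differences from one another. Nothing available here explains the rise.

From the compounds shown here alone, it remains open whether the ring nitrogen of pyridin-2-yl matters, which a plain phenyl group at the same carbon would test, and whether a small amine there would move the number in the same direction. Whether the same swap behaves alike with a chain other than butyl on the shared core also stays unanswered.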